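The source may hold more compounds than are shown below. What is called first, only, known or untested is meant among the compounds shown, and "the series" means these compounds.

In a functional assay on HeLa cells (Homo sapiens) for cytotoxicity, read by MTT assay, with a stated time of 72 h (on this read-out lower numbers stand for stronger inhibition and higher numbers for weaker inhibition), compound 1 `CN1CCN(Cc2nnc(-c3cc(S(N)(=O)=O)c(SCc4ccccc4)cc3Cl)o2)CC1` gives 75000 nM, while compound 2 `NS(=O)(=O)c1cc(-c2nnc(/C=C/c3ccccc3)o2)c(Cl)cc1SCc1ccccc1` gives 14000 nM, the lowest of the two numbers; the change is a 5.4-fold lower number from compound 1 to compound 2 (0.73 log units; beyond the scatter). Compound 3 `NS(=O)(=O)c1cc(-c2nnc(/C=C/c3cccc(Cl)c3)o2)c(Cl)cc1SCc1ccccc1` differs from compound 2 by chloro in place of hydrogen on an aromatic carbon, on the phenyl of the 2-phenylethenyl group. Among the measured compounds shown here, no measured step touches that phenyl, so the only step seen, which replaces a different group, bears on it little. The expected change is therefore small, a 1.3-fold lower number from compound 2 to compound 3 (0.10 log units; within the scatter), within the scatter. Compound 3 is estimated at 11000 nM, with a range from 4000 nM to 30000 nM in this assay.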

Compound 3, half-maximal inhibitory concentration: 16000 nM
For compound 3 the middle estimate is 1.5-fold (0.16 log units) below the measured one; the range from low to high includes it.
By their numbers in this assay, from the lowest: compounds 2 and 3 (each within the scatter of the next); then compound 1.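

In this assay chloro in place of hydrogen on the phenyl of the 2-phenylethenyl group gives a 1.1-fold higher number from compound 2 to compound 3 (0.06 log units; within the scatter) and so leaves the number within the scatter, the first sign that this phenyl takes a substituent without a readable change. The replacement of (4-methylpiperazin-1-yl)methyl still gives a 4.7-fold lower number from compound 1 to compound 3 (0.67 log units; beyond the scatter) when the phenyl carries chloro. No measured evidence accounts for these results. As far as these compounds go, whether a methoxy group, an amine or a carboxylic acid on this phenyl would also leave the number unchanged stays open.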